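Swapping one fluorinated group on compound 3

The source may report more compounds than this note shows. Statements on the series, on what has been measured and on what is new or still open speak of the compounds shown alone.

In a functional assay on VCaP cells (Homo sapiens) for antiproliferative activity, read by propidium iodide staining, with a stated time of 96 h (on this read-out higher numbers stand for weaker inhibition and lower numbers for stronger inhibition), compound 3 (`CC(O)(COc1cccc(S(F)(F)(F)(F)F)c1)C(=O)Nc1cc(C(F)(F)F)cc(C(F)(F)F)c1`) gives 2700 nM as its result. Compound 2 (`CC(O)(COc1ccc(S(F)(F)(F)(F)F)cc1)C(=O)Nc1cc(C(F)(F)F)cc(C(F)(F)F)c1`) gives 2400 nM in the same test, and the two values agree within the usual scatter of repeat measurements. Compound 1 (`CC(O)(COc1ccc(C#N)cc1)C(=O)Nc1ccc(S(F)(F)(F)(F)F)cc1`) gives 100000 nM by comparison, so compound 3 stands well beyond the scatter on the stronger side of it.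

The next molecule, compound 4 (`CC(O)(COc1cccc(C(F)(F)C(F)(F)F)c1)C(=O)Nc1cc(C(F)(F)F)cc(C(F)(F)F)c1`), keeps the rest of compound 3 and alters one group: a group of 7 heavy atoms (2 carbon, 5 fluorine; no ring) in place of a group of 6 heavy atoms (5 fluorine, 1 sulfur; no ring), on an aromatic carbon describes the swap. The incoming group is 1,1,2,2,2-pentafluoroethyl, which sits on an aromatic carbon, meta to a large group. Neither the old group nor the new one has a ring or a net charge.

For the measured compounds named here, no two measured compounds differ in just one place, so the data hold no direct guide to what this swap does in this assay and the expectation is cautious. It rests on compound 3 at 2700 nM as the closest measured neighbour, and no shift beyond the scatter is expected in either direction. The estimated change is a 1.1-fold lower number from compound 3 to compound 4 (0.03 log units; within the scatter) and it stays within the scatter. For compound 4 the expected value is 2500 nM with an estimated range from 1000 nM to 6000 nM as its likely span.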

Compound 4, half-maximal inhibitory concentration: 9500 nM
Estimate against measurement, compound 4: 3.8-fold (0.58 log units) below; the measured number lies above the stated range.
By their numbers in this assay, from the lowest: compounds 2 and 3 (each within the scatter of the next); then compound 4; then compound 1.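

In this assay, for the compounds shown here, the step of a 3.5-fold higher number from compound 3 to compound 4 (0.55 log units; beyond the scatter) gives the first direct reading of a single change. Everything else in the molecule stays the same. On this aromatic carbon, meta to a large group, 1,1,2,2,2-pentafluoroethyl therefore does not stand in freely for the group of five fluorine atoms and one sulfur, even though both carry five fluorine atoms, neither has a ring or a net charge, and neither has a hydrogen-bond donor or acceptor; the swap gives weaker inhibition by more than the usual scatter. No measurement here accounts for this loss, so the step records what happens without showing the reason.

As far as these compounds go, this is a single pair, so it remains open whether the same swap would have a similar effect at another position on this ring or with a different group on the amide nitrogen. It is also unclear how the result would change with a smaller trifluoromethyl group or a longer chain such as heptafluoropropyl at this place, and so whether the loss follows the size of the group or something specific to the sulfur-bearing group.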